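A Phenethyl Swap on the Sulfur of Compound 2

A few compounds are considered here, and "the series" means these few. Any claim that something is new, unique, unknown or untested is made for them only; others in the source may bear on it.

In a functional assay on HeLa cells (Homo sapiens) for inhibition, read by CCK-8 assay, with a stated time of 72 h, tested at 2 uM (a lower number here means less inhibition of growth, a higher number more inhibition of growth at the concentration tested), compound 1 `CCc1ccc(SCc2ccc(/C=C/C(=O)Nc3ccccc3N)cc2)cc1` gives 3.96% and compound 2 `Nc1ccccc1NC(=O)/C=C/c1ccc(CSc2ccc(C(F)(F)F)cn2)cc1` gives 6.07% so compound 2 cannot be told apart from compound 1. Compound 3 `Nc1ccccc1NC(=O)/C=C/c1ccc(CSCCc2ccccc2)cc1` has phenethyl in place of 5-(trifluoromethyl)pyridin-2-yl on a sulfur and has not yet been measured. For the measured compounds named here, the only measured step, a number 2.1 percentage points higher from compound 1 to compound 2 (within the scatter) also swapped the group on the sulfur, and it gives no reason to expect a change beyond the scatter in either direction. The expected change is a number 0.9 percentage points higher from compound 2 to compound 3 (within the scatter) as an estimate only. Compound 3 is therefore estimated at 7% with an expected range of 0% to 18% when tested.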

Compound 3, percent growth inhibition at one concentration: 0.19%
Compound 3: middle estimate off by 6.8 percentage points, on the high side; the range from low to high includes it.
By their numbers in this assay, from the lowest: compounds 3, 1 and 2 (each within the scatter of the next).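

Phenethyl brings a saturated chain to the sulfur, unlike the two groups seen earlier, yet in this assay this change cannot be told apart from either of them (a number 5.9 percentage points lower from compound 2 to compound 3 (within the scatter); a number 3.8 percentage points lower from compound 1 to compound 3 (within the scatter)). All three groups on the sulfur therefore lie within the scatter of one another, with or without a hetero atom in the ring. No supporting measurement bears on this result. Still open, from the compounds shown here alone, is whether a longer chain, or an amine or carboxylic acid at the end of the chain, would move the number beyond the scatter.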